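The compounds below may be only part of what the source reports. "The series", "measured", "known", "first", "only" and "open" are said of these compounds alone.

Compound 1, `CC[C@@H]1C(=O)N(C)c2cnc(Nc3ccc(S(=O)(=O)NCCO)cc3)nc2N1C1CCCC1`, gives 344 nM in a functional assay on MCF7 cells (Homo sapiens) for antiproliferative activity, read by CCK-8 assay, with a stated time of 72 h; a higher number here means a weaker inhibitor of growth, a lower number a stronger inhibitor of growth.
Compound 2, `CCC1C(=O)N(C)c2cnc(Nc3ccc(S(=O)(=O)NCCCO)cc3)nc2N1c1ccn(C)n1`, gives 21600 nM in this assay.

Of the two numbers shown, compound 2 stands with the highest one; its nearest neighbour, compound 1, sits a long way below it, and that gap is well beyond the scatter of repeated measurements. The next compound, compound 3, `CCCNS(=O)(=O)c1ccc(Nc2ncc3c(n2)N(c2ccn(C)n2)C(CC)C(=O)N3C)cc1`, has not yet been measured in this assay. It differs from compound 2 in one place only: hydrogen in place of hydroxy on a saturated chain carbon, three bonds along the chain from a sulfonamide nitrogen. Within the data shown here, no measured pair in this set shows the effect of removing a hydroxy on such a chain, so the expectation rests only on the shared core and on the number compound 2 gives. The change is expected to move the number little, if at all, so the estimated step of a 1.4-fold lower number from compound 2 to compound 3 (0.16 log units; within the scatter) is within or only slightly beyond the scatter. Compound 3 is therefore estimated at 15000 nM, within a range of 5000 nM to 50000 nM.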

Compound 3, concentration for 50% growth inhibition: 3000 nM
Compound 3: the middle estimate sits 5.0-fold (0.70 log units) above what was measured; the whole stated range lies above it.
By their numbers in this assay, from the lowest: compound 1; then compound 3; then compound 2.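

Taking away the hydroxy, the change from 3-hydroxypropyl to propyl, gives the first reading at this position: in this assay it produces a 7.2-fold lower number from compound 2 to compound 3 (0.86 log units; beyond the scatter) and so shows that the chain end is not a silent part of the structure. A saturated chain carbon three bonds along the chain from a sulfonamide nitrogen therefore tolerates losing the hydroxy, and with the shared core unchanged, growth inhibition improves rather than falls. Nothing available accounts for the size or direction of this step. Going by these compounds, whether an amine or a carboxylic acid at the chain end, or a longer chain such as butyl, would shift the number further remains open. So does whether the same removal would act alike on the 2-hydroxyethyl chain of compound 1, whose core carries a different group.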